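A few compounds are considered here, and "the series" means these few. Any claim that something is new, unique, unknown or untested is made for them only; others in the source may bear on it.

Measured compounds: compound 1 `O=C(CSc1nc2ccccc2[nH]1)c1ccc(Br)cc1`, 43000 nM; compound 2 `COc1ccc(C(=O)CSc2nc3ccccc3[nH]2)cc1OC`, 19100 nM.

Among the measured compounds shown here, in a functional assay on HT-29 cells (Homo sapiens) for inhibition, read by WST assay, with a stated time of 48 h (a higher number here means a weaker inhibitor, a lower number a stronger inhibitor), compound 2 gives 19100 nM, the lower of the two numbers measured so far. Compound 1 gives 43000 nM in this assay, a higher number, and the gap between the two lies beyond the scatter. Compound 3 `COc1ccc(C(=O)CSc2nc3ccccc3[nH]2)cc1` has not yet been measured. It differs from compound 2 in one place: hydrogen in place of methoxy on an aromatic carbon, at a position ortho to a methoxy group and meta to a large group. For the measured compounds named here, no pair of measured compounds differs in just this way, so the two measured values give no direct guide to the size of this step. The expected step is a 1.4-fold higher number from compound 2 to compound 3 (0.13 log units; within the scatter), a modest move toward a weaker inhibitor, though one that may not clear the scatter. The estimate for compound 3 in this assay is 26000 nM, with a range from 10000 nM to 65000 nM.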

Compound 3, half-maximal inhibitory concentration: 25200 nM
Compound 3: middle estimate off by 1.0-fold (0.01 log units), on the high side, within the range that was stated.
By their numbers in this assay, from the lowest: compounds 2, 3 and 1 (each within the scatter of the next, the first and the last beyond it).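

In this assay hydrogen in place of methoxy on an aromatic carbon, ortho to a methoxy group and meta to a large group, gives a 1.3-fold higher number from compound 2 to compound 3 (0.12 log units; within the scatter) and so does not separate compound 3 from compound 2. On the same ring, methoxy in place of bromo on an aromatic carbon gives a 1.7-fold lower number from compound 1 to compound 3 (0.23 log units; within the scatter) and so does not separate compound 3 from compound 1 either, which means neither single change can be told from the scatter of repeated measurements. Nothing available here explains these numbers or bears on the result.

From the compounds shown here alone, whether an amine or a carboxylic acid on this aromatic carbon would move the number beyond the scatter remains open. Also open, going by these compounds, is whether a longer chain in place of the remaining methoxy would do so.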